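Replacing pyrrolidin-1-yl on the thiocarbonyl carbon of compound 3

The source may hold more compounds than are shown below. What is called first, only, known or untested is meant among the compounds shown, and "the series" means these compounds.

Of the compounds shown here, three sharing one core have been measured in a functional assay on KYSE-450 cells (Homo sapiens) for inhibition, read by CCK-8 assay, with a stated time of 48 h; a lower number here means a stronger inhibitor, a higher number a weaker inhibitor. Compound 1 (`COc1ccc(CN(C(=O)CSC(=S)N2CCN(C)CC2)c2cc(OC)c(OC)c(OC)c2)cc1`) gives 1250 nM, compound 2 (`CCN1CCN(C(=S)SCC(=O)N(Cc2ccc(OC)cc2)c2cc(OC)c(OC)c(OC)c2)CC1`) gives 3070 nM, and compound 3 (`COc1ccc(CN(C(=O)CSC(=S)N2CCCC2)c2cc(OC)c(OC)c(OC)c2)cc1`) gives 13800 nM, the highest number and so the weakest inhibitor of the three. Compound 4 (`COc1ccc(CN(C(=O)CSC(=S)N2CCc3cc(OC)ccc32)c2cc(OC)c(OC)c(OC)c2)cc1`) differs from compound 3 at one place, on a thiocarbonyl carbon: 5-methoxy-2,3-dihydro-1H-indol-1-yl in place of pyrrolidin-1-yl on a thiocarbonyl carbon. Among the measured compounds shown here, two measured steps concern that same place. One is large, an 11-fold higher number from compound 1 to compound 3 (1.04 log units; beyond the scatter), and the other modest, a 4.5-fold higher number from compound 2 to compound 3 (0.65 log units; beyond the scatter), so the group there clearly moves the number. Neither step tests a group carrying an aromatic ring, which leaves the direction for compound 4 open to some doubt. Still, compound 3 at 13800 nM sits at the top of the measured range, so a fall is thought likelier than a rise. A modest step is expected, a 2.8-fold lower number from compound 3 to compound 4 (0.44 log units; beyond the scatter). For compound 4 the estimated value is 5000 nM, with an expected range from 1200 nM to 20000 nM.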

Compound 4, half-maximal inhibitory concentration: 10200 nM
Compound 4: the middle estimate sits 2.0-fold (0.31 log units) below what was measured; the measured number falls inside the stated range.
By their numbers in this assay, from the lowest: compound 1; then compound 2; then compounds 4 and 3 (each within the scatter of the next).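

In this assay, among the compounds shown here, 5-methoxy-2,3-dihydro-1H-indol-1-yl is the first group on the thiocarbonyl carbon to carry an aromatic ring, and it gives a 1.4-fold lower number from compound 3 to compound 4 (0.13 log units; within the scatter) when it replaces pyrrolidin-1-yl, so these two groups cannot be told apart here. The piperazine groups keep lower numbers against this larger group, with a 3.3-fold higher number from compound 2 to compound 4 (0.52 log units; beyond the scatter) for 4-ethylpiperazin-1-yl and an 8.2-fold higher number from compound 1 to compound 4 (0.91 log units; beyond the scatter) for 4-methylpiperazin-1-yl, so the split among these four compounds runs between the two piperazines and the two other groups. Nothing available explains this split.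

Morpholin-4-yl would show whether the second ring nitrogen of the piperazines matters. The parent 2,3-dihydro-1H-indol-1-yl, without its methoxy, would separate the contribution of the methoxy from that of the aromatic ring.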